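Swapping bromo for methyl on the shared core

A few compounds are considered here, and "the series" means these few. Any claim that something is new, unique, unknown or untested is made for them only; others in the source may bear on it.

Compound 1 `O=C1/C(=C/c2ccccc2Br)NS(=O)(=O)c2ccccc21` was tested in an assay for inhibition of Intestinal-type alkaline phosphatase (Homo sapiens), read by spectrophotometry, with stated times of 10 min and 20 min (on this read-out higher numbers stand for weaker inhibition and lower numbers for stronger inhibition), where compound 1 gives 7430 nM. Its companion in the set, compound 2 `O=C1/C(=C/c2c(F)cccc2F)NS(=O)(=O)c2ccccc21`, gives 10600 nM in this assay. The two numbers lie within the usual scatter of each other, so on this read-out nothing separates compound 1 from compound 2, and compound 1 serves simply as the starting point for the next change.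

Compound 3 `Cc1ccccc1/C=C1\NS(=O)(=O)c2ccccc2C1=O` has not yet been measured. It differs from compound 1 by methyl in place of bromo on an aromatic carbon. For the measured compounds named here, no pair of measured compounds shows this particular change, so the expectation rests on compound 1 alone, whose value of 7430 nM anchors it.

The step from compound 1 to compound 3 is expected to be small, a 1.2-fold higher number from compound 1 to compound 3 (0.08 log units; within the scatter), and not clearly beyond the scatter in either direction. Compound 3 is therefore estimated at 9000 nM, with a range from 3000 nM to 27000 nM.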

Compound 3, half-maximal inhibitory concentration: 3750 nM
The estimate for compound 3 lay 2.4-fold (0.38 log units) above the measured number; low and high end bracket the measured number.
By their numbers in this assay, from the lowest: compounds 3, 1 and 2 (each within the scatter of the next, the first and the last beyond it).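

For the compounds shown here, this is the first measured step at this position: in this assay, methyl in place of bromo on an aromatic carbon, ortho to a large group, gives a 2.0-fold lower number from compound 1 to compound 3 (0.30 log units; within the scatter) and so does not clearly move the read-out. The 2-bromophenyl and 2-methylphenyl forms of the shared core therefore cannot be told apart in this assay, and this one pair shows that the bromo is not required for a measurable number, since compound 3 keeps inhibition with methyl in that place. No measurement at hand bears on what lies behind the similar numbers of these two groups.

On these data alone, what remains open is how far this position tolerates a real change of group: an amine, a carboxylic acid or a longer chain such as propyl in the same place could each give a step beyond the scatter, or none at all. As far as these compounds go, it also remains open whether methyl in place of bromo would read the same way at another place on this aromatic ring, as this single pair speaks only for the one position.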